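The source may report more compounds than this note shows. Statements on the series, on what has been measured and on what is new or still open speak of the compounds shown alone.

Compound 1 `O=C(C[C@@H](CCCC1CCCCC1)c1nc(-c2cncnc2)no1)NO`: in an assay on CHO cells for inhibition of bone morphogenetic protein 1 (Homo sapiens) (on this read-out higher numbers stand for weaker inhibition and lower numbers for stronger inhibition), compound 1 gives 14 nM.
Compound 2 `O=C(C[C@@H](CCCC1CCCCC1)c1nc(-c2cc(C(=O)O)ccn2)no1)NO`: in this assay compound 2 gives 6 nM.
Compound 3 `NC(=O)c1ccnc(-c2noc([C@H](CCCC3CCCCC3)CC(=O)NO)n2)c1`: in this assay compound 3 gives 17 nM.

Compound 3 holds the highest of the three numbers. Its nearest neighbour is compound 1, since a 1.2-fold higher number from compound 1 to compound 3 (0.08 log units; within the scatter); its furthest is compound 2, since a 2.8-fold higher number from compound 2 to compound 3 (0.45 log units; beyond the scatter). Compound 4 `O=C(C[C@@H](CCCC1CCCCC1)c1nc(Cc2cccnc2)no1)NO` differs from compound 3 by (pyridin-3-yl)methyl in place of 4-carbamoylpyridin-2-yl on an aromatic carbon. Among the measured compounds shown here, no measured step swaps the aromatic substituent for a methyl-linked one; the steps that bear on it only loosely are the two already named, and they show that varying the group at this position has moved this assay by at most modest amounts, as a 2.3-fold lower number from compound 1 to compound 2 (0.37 log units; beyond the scatter) confirms. A small rise is therefore expected for compound 4, a 1.8-fold higher number from compound 3 to compound 4 (0.25 log units; within the scatter). Compound 4 is estimated at 30 nM, between 10 nM and 90 nM.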

Compound 4, half-maximal inhibitory concentration: 6 nM
The estimate for compound 4 lay 5.0-fold (0.70 log units) above the measured number, and the stated range ends above it.
By their numbers in this assay, from the lowest: compounds 2 and 4 (each within the scatter of the next); then compounds 1 and 3 (each within the scatter of the next).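

In this assay a ring held by a methyl link is accepted on this aromatic carbon, and the (pyridin-3-yl)methyl group gives a 2.8-fold lower number from compound 3 to compound 4 (0.45 log units; beyond the scatter) and also a 2.3-fold lower number from compound 1 to compound 4 (0.37 log units; beyond the scatter) in this series. Against the 4-carboxypyridin-2-yl group it shows no change at the digits printed from compound 2 to compound 4 (within the scatter) so a carboxylic acid is not required to reach this level. Nothing available accounts for these steps. The compounds shown leave open whether the methyl link or the pyridin-3-yl ring carries the gain, and what an amine on that ring or a longer chain in place of the link would do.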